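The compounds below may be only part of what the source reports. "The series", "measured", "known", "first", "only" and "open" are said of these compounds alone.

Measured so far in a functional assay on HCT-116 cells (Homo sapiens) for cytotoxicity, read by MTT assay, with a stated time of 72 h; on this read-out lower numbers stand for stronger inhibition and higher numbers for weaker inhibition:
compound 1, `COc1cc(Nc2nc3ccccc3nc2S(=O)(=O)c2ccccc2)cc(OC)c1OC`: > 50000 nM
compound 2, `COc1cc(Nc2nc3ccccc3nc2S(=O)(=O)c2ccc(C)cc2)cc(OC)c1OC`: 10800 nM
compound 3, `COc1ccc(S(=O)(=O)c2nc3ccccc3nc2Nc2cc(OC)cc(OC)c2)cc1`: 13400 nM

The value of compound 1 is a limit of this assay, not a number, and it sits at the limit of > 50000 nM in this assay, at which 1 of the 3 values shown sits. Compound 3 stands at the higher of the two actual numbers; compound 2 is its nearest neighbour, and the two lie within the scatter of each other. For the measured compounds named here, the one single-point step in the set is an at least 4.6-fold lower number from compound 1 to compound 2 (0.66 log units; beyond the scatter); it concerns the aryl ring attached to the sulfonyl group and does not touch the anilino ring that is changed here.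

Compound 4, `COc1ccc(S(=O)(=O)c2nc3ccccc3nc2Nc2cc(OC)c(OC)c(OC)c2)cc1`, differs from compound 3 by methoxy in place of hydrogen on an aromatic carbon. Going by the values given here, no measured step bears on this change directly. Among the compounds with values here, compound 2 already carries the trimethoxy anilino ring on the shared core and gives 10800 nM, close to compound 3 with its dimethoxy pattern; this is the only guidance, and it points to a small step. The expectation for compound 4 in this assay is therefore a 1.3-fold lower number from compound 3 to compound 4 (0.13 log units; within the scatter), a change not expected to exceed the scatter. Compound 4 is estimated at 10000 nM, with a range from 4000 nM to 30000 nM.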

Compound 4, half-maximal inhibitory concentration: > 50000 nM
Compound 4 was reported as a limit; the forecaster's own chance of this, stated with the estimate: 10%; at least 5.0-fold (0.69 log units) between middle value and limit.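

In this assay compound 4 gives > 50000 nM, which is a limit of the assay and not a number: the limit of > 50000 nM in this assay, at which 2 of the 4 values shown sit.

The added methoxy, ortho to two methoxy groups on the anilino ring, is not a silent change in this series when the ring attached to the sulfonyl group carries methoxy: an at least 3.7-fold higher number from compound 3 to compound 4 (0.57 log units; beyond the scatter). With the trimethoxy anilino ring kept, methoxy in place of methyl on the sulfonyl-attached ring also moves the result beyond the scatter, an at least 4.6-fold higher number from compound 2 to compound 4 (0.66 log units; beyond the scatter), so the two rings cannot be read independently in these compounds, and methyl and methoxy are not interchangeable on the trimethoxy series; the step between compound 1 and compound 4 cannot be read, as both ends are limits.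

The compounds shown leave open whether a chlorine, an ethyl group or a hydroxyl group in place of that methoxy on the sulfonyl-attached ring would bring the trimethoxy series back to a measurable number. They also leave open whether the methyl-bearing sulfonyl ring depends on the third methoxy of the anilino ring at all, and whether an amine in that place on the anilino ring would behave as methoxy does.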